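This account rests on a few compounds, and the source may have more. Where it says the series, first, only, none or still open, it means among the compounds named here.

Measured compounds:
compound 1 `CN(CCC#N)C[C@H]1CN(c2ccc(-n3cc(-c4ccccn4)cn3)c(F)c2)C(=O)O1`, 1.9
compound 2 `O=C1O[C@@H](CN2CCCCC2)CN1c1ccc(-n2cc(-c3ccccn3)cn2)c(F)c1`, 3.1
compound 3 `O=C1CSC(=O)N1C[C@H]1CN(c2ccc(-n3cc(-c4ccccn4)cn3)c(F)c2)C(=O)O1`, 2.18

In a physicochemical assay for lipophilicity, read by HPLC, measured as octanol-water partition (on this read-out lower numbers stand for lower lipophilicity and higher numbers for higher lipophilicity), compound 3 stands second highest of the three: compound 1 sits within the scatter of it, while compound 2 lies beyond it, with a number 0.92 log units lower from compound 2 to compound 3 (beyond the scatter). Compound 4 `COC(=O)NC[C@H]1CN(c2ccc(-n3cc(-c4ccccn4)cn3)c(F)c2)C(=O)O1` is not yet measured; it differs from compound 3 by (methoxycarbonyl)amino in place of 2,4-dioxo-1,3-thiazolidin-3-yl on a saturated chain carbon bound to a saturated ring carbon.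

Among the measured compounds shown here, two steps bear on this position. a number 0.28 log units higher from compound 1 to compound 3 (within the scatter) shows that exchanging one neutral, uncharged substituent for another there leaves this assay essentially unchanged, whereas a number 0.92 log units lower from compound 2 to compound 3 (beyond the scatter) shows a modest shift only when the piperidin-1-yl group is involved. Compound 4 keeps a neutral group, so a step of a number 0.18 log units lower from compound 3 to compound 4 (within the scatter) is expected, at most marginally beyond the scatter. The value of compound 4 is estimated at 2, with a range from 1.6 to 2.4.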

Compound 4, partition coefficient: 2.03
Compound 4: middle estimate off by 0.03 log units, on the low side; low and high end bracket the measured number.
By their numbers in this assay, from the lowest: compounds 1, 4 and 3 (each within the scatter of the next); then compound 2.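

In this assay the (methoxycarbonyl)amino group, with no ring and a hydrogen-bond donor, gives a number 0.15 log units lower from compound 3 to compound 4 (within the scatter) and also a number 0.13 log units higher from compound 1 to compound 4 (within the scatter) on the saturated chain carbon bound to a saturated ring carbon. Three different groups there now read alike, and only piperidin-1-yl stands apart, with a number 1.07 log units lower from compound 2 to compound 4 (beyond the scatter) as the third step separating it from the others. No measured evidence accounts for these steps.

As far as these compounds go, whether the gap belongs to piperidin-1-yl alone or extends to other amines stays open. A morpholin-4-yl group, a primary amine or a carboxylic acid in this place would test that.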